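The source may hold more compounds than are shown below. What is called first, only, known or untested is meant among the compounds shown, and "the series" means these compounds.

Working notes on the series. Two compounds have numbers in a functional assay on the whole organism (strain Swiss albino) with Mus musculus as the target, in the maximal electroshock model, with a stated time of 0.5 h; on this read-out higher numbers stand for an effect only at larger amounts of compound and lower numbers for an effect already at smaller amounts. Compound 1 `COc1cc(/C=N/NC(=O)Nc2cccc3ccccc23)cc(OC)c1OC` gives 100 mg/kg. Compound 2 `COc1cc(/C=N/NC(=O)Nc2cccc3ccccc23)ccc1O` gives 300 mg/kg, the highest of the two numbers; compound 1 sits at a lower number, and the gap lies beyond the scatter. Compound 3 `COc1ccc(/C=N/NC(=O)Nc2cccc3ccccc23)cc1OC` is not yet measured. It differs from compound 2 by methyl in place of hydrogen on an oxygen on an aromatic ring. For compound 3 a downward step of a 2.0-fold lower number from compound 2 to compound 3 (0.30 log units; within the scatter) is expected, because compound 1, carrying methoxy throughout, gives 100 mg/kg. Compound 3 is estimated at 150 mg/kg, with a range from 70 mg/kg to 300 mg/kg.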

Compound 3, minimum effective dose: 100 mg/kg
The estimate for compound 3 lay 1.5-fold (0.18 log units) above the measured number, within the range that was stated.
By their numbers in this assay, from the lowest: compounds 1 and 3 (each within the scatter of the next); then compound 2.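

Hydroxy to methoxy brings a 3.0-fold lower number from compound 2 to compound 3 (0.48 log units; beyond the scatter) and is the first single-place step in the series, so this oxygen on an aromatic ring is a place the read-out responds to. Hydrogen in place of methoxy on an aromatic carbon gives no change at the digits printed from compound 1 to compound 3 (within the scatter) and so the extra methoxy of compound 1 is not needed to reach this level. No measurement at hand accounts for either step. Open, as far as these compounds go, is whether a longer chain such as ethyl or propyl on that oxygen holds the level of compound 3. Equally open, from the compounds shown here alone, is how an amine in place of the methoxy would read.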